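A few compounds are considered here, and "the series" means these few. Any claim that something is new, unique, unknown or untested is made for them only; others in the source may bear on it.

In a functional assay on EOL1 cells (Homo sapiens) for inhibition, read by fluorescence, with a stated time of 72 h (on this read-out lower numbers stand for stronger inhibition of growth and higher numbers for weaker inhibition of growth), compound 1 `CCCCCCn1cnc2c(Nc3ccc(Cl)cc3)nc(N[C@H]3CC[C@H](N)CC3)nc21` gives 440 nM. Compound 2 `CCCCCCn1cnc2c(Nc3cc(OC)cc(OC)c3)nc(N[C@H]3CC[C@H](N)CC3)nc21` gives 380 nM, and a 1.2-fold lower number from compound 1 to compound 2 (0.06 log units; within the scatter) leaves the two level. Compound 3 `CCCCCCn1cnc2c(Nc3ccc(O)cc3)nc(N[C@H]3CC[C@H](N)CC3)nc21` gives 190 nM, and with a 2.3-fold lower number from compound 1 to compound 3 (0.36 log units; beyond the scatter) its number lies clearly under that of compound 1, while a 2.0-fold lower number from compound 2 to compound 3 (0.30 log units; within the scatter) separates it from compound 2 by no more than the scatter.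

Compound 4 `CCCCn1cnc2c(Nc3ccc(Cl)cc3)nc(N[C@H]3CC[C@H](N)CC3)nc21` keeps the 4-chlorophenyl of compound 1 and changes only the chain: hydrogen in place of ethyl on a saturated chain carbon, four bonds along the chain from an aromatic nitrogen. None of the three measured steps touches this chain. All of them change the aromatic group on the nitrogen, so they bear on the new step only indirectly, as a guide to how far values have moved in this small set. The data therefore give no direction for shortening the chain, and no step beyond the scatter is expected in this assay. The expected change is a 1.1-fold higher number from compound 1 to compound 4 (0.06 log units; within the scatter), a size that is an estimate only. For compound 4 the estimated value is 500 nM, with an expected range from 170 nM to 1500 nM.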

Compound 4, concentration for 50% growth inhibition: 50 nM
Estimate against measurement, compound 4: 10-fold (1.00 log units) above; measured number outside the range, below it.
By their numbers in this assay, from the lowest: compound 4; then compounds 3, 2 and 1 (each within the scatter of the next, the first and the last beyond it).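

In this assay, hydrogen in place of ethyl on a saturated chain carbon, four bonds along the chain from an aromatic nitrogen, gives an 8.8-fold lower number from compound 1 to compound 4 (0.94 log units; beyond the scatter) with the 4-chlorophenyl group left unchanged. Going by these compounds alone, this chain step is larger than a 2.3-fold lower number from compound 1 to compound 3 (0.36 log units; beyond the scatter), the only earlier step that lay beyond the scatter, so the chain is a position at which the read-out moves markedly, something that compound 1, compound 2 and compound 3 could not show because they all carry the same chain. No measured information accompanies this result to explain why the butyl chain of compound 4 gives so much stronger inhibition of growth than the longer chain of compound 1.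

The compounds shown leave open whether the number keeps falling with a still shorter chain, such as propyl or ethyl, or whether an amine or a carboxylic acid at the end of the chain would be tolerated. They also leave open whether the same chain change would give a step of similar size with the 4-hydroxyphenyl group of compound 3 or the 3,5-dimethoxyphenyl group of compound 2.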